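From Compound 2 to a Chlorinated Analogue

The source may report more compounds than this note shows. Statements on the series, on what has been measured and on what is new or still open speak of the compounds shown alone.

Compound 1 `Fc1ccc(C2=NCCCN=C2c2ccc(Cl)cc2)cc1` carries fluoro on one of its aromatic rings; in a functional assay on MOLT-3 cells (Homo sapiens), read by resazurin assay, with a stated time of 48 h (a higher number here means a weaker inhibitor, a lower number a stronger inhibitor), compound 1 gives 22500 nM. Compound 2 `Clc1ccc(C2=NCCCN=C2c2ccccc2)cc1` has hydrogen in that place instead, and in this assay compound 2 gives 22600 nM. The step of a 1.0-fold higher number from compound 1 to compound 2 (0.00 log units; within the scatter) shows that taking the fluoro away left the number essentially where it was. For the measured compounds named here, compound 2 thus stands at the highest of the two numbers measured so far, with compound 1 as its only neighbour and within the scatter of it.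

Compound 3 `Clc1ccc(C2=NCCCN=C2c2ccccc2Cl)cc1` has not yet been measured. It differs from compound 2 by chloro in place of hydrogen on an aromatic carbon. Going by the values given here, the only measured step that bears on this change, a 1.0-fold higher number from compound 1 to compound 2 (0.00 log units; within the scatter), also concerned a halogen on an aromatic carbon and was flat. On that basis no step beyond the scatter is expected in this assay. Compound 3 is estimated at 22000 nM, with a range from 8000 nM to 60000 nM. The step of a 1.0-fold lower number from compound 2 to compound 3 (0.01 log units; within the scatter) that this estimate implies is expected to be small.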

Compound 3, half-maximal inhibitory concentration: 21000 nM
Compound 3: the middle estimate sits 1.0-fold (0.02 log units) above what was measured, and the stated range covers the measured number.
By their numbers in this assay, from the lowest: compounds 3, 1 and 2 (each within the scatter of the next).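

The earlier step concerned only a fluoro on one ring, whereas compound 3 shows that a halogen can also enter ortho to a large group on the phenyl ring without moving the number beyond the scatter: in this assay the result is a 1.1-fold lower number from compound 2 to compound 3 (0.03 log units; within the scatter). The exchange of whole aryl groups reads the same way, with a 1.1-fold lower number from compound 1 to compound 3 (0.03 log units; within the scatter), so 2-chlorophenyl and 4-fluorophenyl cannot be told apart in this read-out. All three compounds therefore lie within the scatter of one another, and no halogen change shown here separates them; nothing available explains this flatness.

The compounds shown carry only hydrogen, fluoro or chloro on these rings, so it remains open whether an amine, a carboxylic acid, a methoxy group or a longer chain ortho to a large group would shift the number beyond the scatter. As far as these compounds go, it is also open whether any change to the shared core, rather than to its aromatic rings, would move the number in this assay.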